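From methyl to trifluoromethyl at the assay limit

The source may report more compounds than this note shows. Statements on the series, on what has been measured and on what is new or still open speak of the compounds shown alone.

In a functional assay on KB cells (Homo sapiens) for inhibition (a higher number here means a weaker inhibitor, a lower number a stronger inhibitor), compound 1 (`Clc1cc2nc(Br)n(Cc3ccccc3)c2cc1Cl`) gives > 100000 nM, which is a limit and not a number. Compound 2 (`Clc1ccc(Cn2c(Br)nc3cc(Cl)c(Cl)cc32)cc1`) gives > 100000 nM, also a limit. Compound 3 (`Cc1ccc(Cn2c(Br)nc3cc(Cl)c(Cl)cc32)cc1`) gives > 100000 nM, again only a limit.

Compound 4 (`FC(F)(F)c1ccc(Cn2c(Br)nc3cc(Cl)c(Cl)cc32)cc1`) carries trifluoromethyl in place of methyl on an aromatic carbon, para to a large group: trifluoromethyl in place of methyl on an aromatic carbon.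

The measured changes that bear on this are a step that the two limits leave unreadable from compound 1 to compound 2, a step that the two limits leave unreadable from compound 1 to compound 3 and a step that the two limits leave unreadable from compound 2 to compound 3, so none offers a size to carry over. Compound 3 shares the limit of > 100000 nM in this assay, at which 3 of the 3 values shown sit, with the others, so no step beyond the scatter is expected in this assay.

The expected step is a number no higher from compound 3 to compound 4 (the limit leaves the size open).

Compound 4 is expected near 100000 nM, with an estimated range of 30000 nM to 300000 nM.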

Compound 4, half-maximal inhibitory concentration: > 100000 nM
Compound 4: a limit, no number; the forecaster's own chance of this, stated with the estimate: 85%; the middle value sits exactly at the limit.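

In this assay compound 4 gives > 100000 nM, a limit and not a number. Its steps from compound 1, compound 2 and compound 3 therefore cannot be read: the limit of > 100000 nM in this assay, at which 4 of the 4 values shown sit. The compounds shown leave open whether these ring substituents differ in inhibition at all.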